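Trifluoromethyl in place of chloro on the shared core

A few compounds are considered here, and "the series" means these few. Any claim that something is new, unique, unknown or untested is made for them only; others in the source may bear on it.

In an ADME assay on microsomes from liver (Homo sapiens) for metabolic stability, read by LC-MS, using NADPH, with stated times of 6 min and 10 min, tested at 0.5 uM (on this read-out lower numbers stand for a less stable compound and higher numbers for a more stable compound), compound 1 `CC(=O)N1CCN(c2cc(-c3cc(Cl)c4c(N)ncnn34)ccc2C(F)(F)F)C(=O)C1(C)C` gives 95%. Among the measured compounds shown here, compound 2 `CC(=O)N1CCN(c2cc(-c3cc(Cl)c4c(N)ncnn34)ccc2Cl)C(=O)C1(C)C`, the only other compound measured, gives 85%. For the measured compounds named here, the two values lie within the scatter of each other, so compound 1 cannot be separated from its sole neighbour on this read-out.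

Compound 3 `CC(=O)N1CCN(c2cc(-c3cc(C(F)(F)F)c4c(N)ncnn34)ccc2C(F)(F)F)C(=O)C1(C)C` has not yet been measured. It differs from compound 1 as follows: trifluoromethyl in place of chloro on an aromatic carbon. This is trifluoromethyl in place of chloro on an aromatic carbon of a five-membered aromatic ring with 1 nitrogen, part of a fused or bridged system of two rings.

Going by the values given here, only one measured step bears on this change, and only indirectly: a number 10 percentage points lower from compound 1 to compound 2 (within the scatter). That step exchanges the same two groups in the opposite sense and at a different place. No change on the five-membered ring itself has been measured.

With that single step as a guide, no shift beyond the scatter is expected in this assay, and the estimated step is a number 5 percentage points lower from compound 1 to compound 3 (within the scatter). For compound 3 the expected value is 90%, with an estimated range from 74% to 100%.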

Compound 3, percent of the compound remaining: 70%
The estimate for compound 3 lay 20 percentage points above the measured number; measured number below the stated range.
By their numbers in this assay, from the lowest: compound 3; then compounds 2 and 1 (each within the scatter of the next).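

In this assay, the position on the five-membered aromatic ring proves sensitive to this exchange: trifluoromethyl in place of chloro there gives a number 25 percentage points lower from compound 1 to compound 3 (beyond the scatter), a step that can be told apart from the usual spread of repeat measurements. Among the compounds shown here, the earlier compounds could not show this, as their only step, a number 10 percentage points lower from compound 1 to compound 2 (within the scatter), exchanged the same two groups in the opposite sense at a different place and stayed within the scatter, so that step does not carry over to this position. Nothing available here bears on why the number falls with this change at this position.

Going by these compounds, it remains open how other groups on this aromatic carbon, such as a methyl, a nitrile or an amine, would compare with chloro and trifluoromethyl in this assay. On these data alone, it is also open whether the same exchange on this ring would give a step of similar size on the core of compound 2, which carries chloro in place of the other trifluoromethyl.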